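Sulfur-chain variants on the shared core

The compounds below may be only part of what the source reports. "The series", "measured", "known", "first", "only" and "open" are said of these compounds alone.

Compound 3 `CC(C)S(=O)(=O)CCC12CCC(c3nnc(-c4ccccc4C(F)(F)F)n3C)(CC1)CC2` in an assay on CHO-K1 cells for inhibition of 11-beta-hydroxysteroid dehydrogenase type 2 (Mus musculus), read by scintillation proximity assay (on this read-out lower numbers stand for stronger inhibition and higher numbers for weaker inhibition), gives only a limit, > 4000 nM. Compound 1 `CCSCCC12CCC(c3nnc(-c4ccccc4C(F)(F)F)n3C)(CC1)CC2` likewise gives only a limit, > 4000 nM. Compound 2 `Cn1c(-c2ccccc2C(F)(F)F)nnc1C12CCC(CCS(C)(=O)=O)(CC1)CC2` also gives only a limit, > 4000 nM. All three values sit at the limit of > 4000 nM in this assay, at which 3 of the 3 values shown sit, so a step that the two limits leave unreadable from compound 1 to compound 3 and a step that the two limits leave unreadable from compound 2 to compound 3 have no readable size, and the same holds for a step that the two limits leave unreadable from compound 1 to compound 2. Compound 4 `CCS(=O)(=O)CCCCC12CCC(c3nnc(-c4ccccc4C(F)(F)F)n3C)(CC1)CC2` carries 2-(ethylsulfonyl)ethyl in place of isopropylsulfonyl on a saturated chain carbon, two bonds along the chain from a saturated ring carbon. The measured steps that bear on this change, each a swap of the sulfur group on the chain, are all unreadable, and nothing shown places any member of the set inside the measurable range. The expectation is therefore that compound 4 also sits at the limit, with a step that the limit leaves unreadable from compound 3 to compound 4 not readable beyond the scatter. Compound 4 is estimated at 6000 nM, in a range from 3000 nM to 20000 nM.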

Compound 4, half-maximal inhibitory concentration: > 4000 nM
Compound 4: only a limit was reported; the forecaster's own chance of this, stated with the estimate: 85%; the middle value does not contradict the limit.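

Compound 4 gives only a limit, > 4000 nM. No step to it from compound 1, compound 2 or compound 3 can be read: the limit of > 4000 nM in this assay, at which 4 of the 4 values shown sit.

The compounds shown leave open whether any sulfur chain on the shared core gives a value inside the measurable range in this assay.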